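The source may hold more compounds than are shown below. What is called first, only, known or untested is meant among the compounds shown, and "the series" means these compounds.

In a functional assay on the whole organism for inhibition, with Mus musculus as the target (a lower number here means that less compound is needed, a higher number that more compound is needed for the effect), three compounds have been measured so far. Compound 3 (`CCNCC(=O)Nc1cccc2c1CN(C)CC2c1ccccc1`) gives 47 mg/kg and lies within the scatter of compound 1 (`CCCCNC(=O)Nc1cccc2c1CN(C)CC2c1ccc(Cl)cc1`) at 44 mg/kg on the same read-out. Apart from both stands compound 2 (`CCOC(=O)Nc1cccc2c1CN(C)CC2c1ccc(Cl)cc1`) at 4.8 mg/kg as the lowest number of the three.

Compound 4 (`CCNCC(=O)Nc1cccc2c1CN(C)CC2c1ccc(Cl)cc1`) keeps the side chain of compound 3 and differs from it in one place, with chloro in place of hydrogen on an aromatic carbon, so that phenyl becomes 4-chlorophenyl (chloro in place of hydrogen on an aromatic carbon). For the measured compounds named here, the only measured step is a 9.2-fold lower number from compound 1 to compound 2 (0.96 log units; beyond the scatter) and it is modest. That step puts ethoxy in place of butylamino on a carbonyl carbon, with the 4-chlorophenyl group present on both sides, so it does not speak directly to the chloro change. Going by the values given here, no measured pair isolates that change, and the two chlorinated compounds already sit far apart. The expected step is therefore small, a 1.9-fold lower number from compound 3 to compound 4 (0.27 log units; within the scatter) in this assay and not beyond the scatter, with only a tentative lean towards a lower number. Compound 4 is estimated at 25 mg/kg with an expected range from 7 mg/kg to 80 mg/kg on this uncertain footing.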

Compound 4, dose for half-maximal effect: 24 mg/kg
Compound 4: the middle estimate sits 1.0-fold (0.02 log units) above what was measured; low and high end bracket the measured number.
By their numbers in this assay, from the lowest: compound 2; then compounds 4, 1 and 3 (each within the scatter of the next).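

In this assay, chloro in place of hydrogen on an aromatic carbon, para to a large group, can now be read on its own, and turning phenyl into 4-chlorophenyl gives a 2.0-fold lower number from compound 3 to compound 4 (0.29 log units; within the scatter), so with this side chain the change does not clear the usual scatter. With the 4-chlorophenyl group held constant, the group on the carbonyl carbon can also be compared directly: (ethylamino)methyl in place of ethoxy gives a 5.0-fold higher number from compound 2 to compound 4 (0.70 log units; beyond the scatter), whereas (ethylamino)methyl in place of butylamino gives a 1.8-fold lower number from compound 1 to compound 4 (0.26 log units; within the scatter), so ethoxy stands apart while the other two cannot be told apart in this assay. Nothing available here accounts for either the small chloro step or the larger ethoxy step.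

From the compounds shown here alone, whether chloro gives a similarly small step alongside the ethoxy carbonyl of compound 2 remains open, as does the outcome with fluoro, methoxy or a second chloro on the aromatic ring. Also open, going by these compounds, is how a longer alkoxy chain such as butoxy, or a piperidine in place of the ethylamino group, would compare in this assay.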